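Phenyl substitution in the pyrrolidine amide series: ester analogue

The source may hold more compounds than are shown below. What is called first, only, known or untested is meant among the compounds shown, and "the series" means these compounds.

Within the data shown here, compound 1 `O=C(CCCCCCc1ccccc1)N1CCCC1` is the unsubstituted parent of the series, and in an assay on HEK293 cells for inhibition of N-acylethanolamine-hydrolyzing acid amidase (Rattus norvegicus), read by LC-MS, with a stated time of 30 min (a higher number here means a weaker inhibitor, a lower number a stronger inhibitor), compound 1 gives 12900 nM, the only plain number so far. Compound 2 `O=C(CCCCCCc1ccccc1Cl)N1CCCC1` carries chloro in place of hydrogen on an aromatic carbon, and in this assay compound 2 reaches only the limit > 100000 nM. Compound 3 `COc1cccc(CCCCCCC(=O)N2CCCC2)c1` carries methoxy in place of hydrogen on an aromatic carbon, and in this assay compound 3 likewise reaches only the limit > 100000 nM. Both steps are therefore bounded from below: an at least 7.7-fold higher number from compound 1 to compound 2 (0.88 log units; beyond the scatter) and an at least 7.7-fold higher number from compound 1 to compound 3 (0.88 log units; beyond the scatter), each resting on (the limit of > 100000 nM in this assay, at which 2 of the 3 values shown sit).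

Compound 4 `COC(=O)c1ccc(CCCCCCC(=O)N2CCCC2)cc1` differs from compound 1 by methoxycarbonyl in place of hydrogen on an aromatic carbon. Neither measured step covers this group or this place, but both substitutions of the aromatic ring seen so far, chloro and methoxy, moved the number to the limit. On that basis a higher number is expected in this assay for compound 4 as well, a step of a 4.7-fold higher number from compound 1 to compound 4 (0.67 log units; beyond the scatter), with a fair chance that only a limit is returned. The estimate for compound 4 in this assay is 60000 nM, in a range of 20000 nM to 200000 nM.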

Compound 4, half-maximal inhibitory concentration: > 100000 nM
Compound 4 gave a limit, no number; the forecaster's own chance of this, stated with the estimate: 50%; at least 1.6-fold (0.22 log units) between middle value and limit.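

Methoxycarbonyl in place of hydrogen, on an aromatic carbon para to a large group, gives an at least 7.7-fold higher number from compound 1 to compound 4 (0.88 log units; beyond the scatter) in this assay. This extends the pattern to a third ring substituent: after chloro and methoxy, a group with a double bond outside the aromatic ring and 2 hydrogen-bond acceptors also leaves no plain number, and among the compounds shown, none with a substituted ring goes against this. The step is a lower bound only, and the three steps from compound 1 cannot be ranked against one another, since the value of compound 4 is a limit and not a number, as are those of compound 2 and compound 3: the limit of > 100000 nM in this assay, at which 3 of the 4 values shown sit.

The compounds shown therefore leave the true values of the three substituted compounds unknown, and they cannot separate the effect of the group from the effect of its place on the ring. Also open, going by these compounds, is whether fluoro, methyl, an amine or a carboxylic acid at this same place would return a plain number in this assay, and whether any of these would fall below that of compound 1.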